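A few compounds are considered here, and "the series" means these few. Any claim that something is new, unique, unknown or untested is made for them only; others in the source may bear on it.

Measured so far:
- compound 1 `CC1(C)CO[C@H]1CN([C@H](CCC(F)(F)F)C(N)=O)S(=O)(=O)c1ccc(Cl)cc1` — 26.4 10^-6 cm/s
- compound 2 `NC(=O)[C@@H](CCC(F)(F)F)N(C[C@H]1CCCOC1)S(=O)(=O)c1ccc(Cl)cc1` — 18.2 10^-6 cm/s
- compound 3 `NC(=O)[C@@H](CCC(F)(F)F)N(C[C@@H]1COCCO1)S(=O)(=O)c1ccc(Cl)cc1` — 27.3 10^-6 cm/s

Compound 1 stands second highest of the three in an ADME assay on MDCKII-LE cells (Canis lupus familiaris) for permeability, read by transwell migration, in the apical to basolateral direction; on this read-out higher numbers stand for higher permeability and lower numbers for lower permeability; its nearest neighbour is compound 3 (a 1.0-fold higher number from compound 1 to compound 3 (0.01 log units; within the scatter)) and its furthest is compound 2 (a 1.5-fold lower number from compound 1 to compound 2 (0.16 log units; within the scatter)), both within the scatter. Compound 2 and compound 3 also sit within the scatter of each other (a 1.5-fold higher number from compound 2 to compound 3 (0.18 log units; within the scatter)). Across the three, the group on the saturated chain carbon bound to the sulfonamide nitrogen has been varied without any step in this assay leaving the scatter.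

Compound 4 `NC(=O)[C@@H](CCC(F)(F)F)N(C[C@H]1COCCO1)S(=O)(=O)c1ccc(Cl)cc1` is not yet measured. Relative to compound 1 it carries the change (1,4-dioxan-2-yl in place of 3,3-dimethyloxetan-2-yl on a saturated chain carbon bound to a sulfonamide nitrogen). The most direct precedent is the step to compound 3, which bears the same 1,4-dioxan-2-yl group with the other defined stereocentre, and which gave a 1.0-fold higher number from compound 1 to compound 3 (0.01 log units; within the scatter). The step to compound 2 (a 1.5-fold lower number from compound 1 to compound 2 (0.16 log units; within the scatter)) points the same way: ring changes at this position have so far moved this assay by no more than the scatter. A step of no more than the scatter is therefore expected for compound 4, a 1.0-fold lower number from compound 1 to compound 4 (0.01 log units; within the scatter), with the estimate resting on the measured value of compound 3, 27.3 10^-6 cm/s. Compound 4 is expected to give about 26 10^-6 cm/s in this assay, within 16 10^-6 cm/s to 40 10^-6 cm/s.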

Compound 4, apparent permeability: 20.6 10^-6 cm/s
The estimate for compound 4 lay 1.3-fold (0.10 log units) above the measured number; measured number inside the range.
By their numbers in this assay, from the lowest: compounds 2, 4, 1 and 3 (each within the scatter of the next).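

In this assay, within the data shown here, the configuration of the 1,4-dioxan-2-yl group can now be read on its own, and it leaves the number within the scatter (a 1.3-fold lower number from compound 3 to compound 4 (0.12 log units; within the scatter)), in the one comparison here that isolates configuration: the fact that compounds 3 and 4 differ only in the configuration as drawn. The exchange of 3,3-dimethyloxetan-2-yl for 1,4-dioxan-2-yl thus stays within the scatter for both drawn configurations, with compound 4 adding a second reading (a 1.3-fold lower number from compound 1 to compound 4 (0.11 log units; within the scatter)). Compound 4 also cannot be separated from the oxan-3-yl compound (a 1.1-fold higher number from compound 2 to compound 4 (0.05 log units; within the scatter)), so all four compounds lie within the scatter of one another in this assay.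

The compounds shown leave open whether an amine or a carboxylic acid at this position would stay within that scatter. They also leave open whether this tolerance holds on any core other than the shared one.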